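Swapping the aryl group on the piperazine nitrogen for a nitrophenyl

The source may hold more compounds than are shown below. What is called first, only, known or untested is meant among the compounds shown, and "the series" means these compounds.

Three compounds sharing one core have been run in a functional assay on CHO cells with adenosine receptor A1 (Homo sapiens) as the target, read by cAMP accumulation and immunoassay, with a stated time of 6 min, tested at 0.01 uM; on this read-out lower numbers stand for a stronger effect and higher numbers for a weaker effect at the one concentration tested. Compound 1 `CC(C)N1CCN(Cc2csc(N)c2C(=O)c2ccc(Cl)cc2)CC1` gives -1%. Compound 2 `Nc1scc(CN2CCN(c3ccc(Cl)cc3Cl)CC2)c1C(=O)c1ccc(Cl)cc1` gives 2%, and compound 3 `Nc1scc(CN2CCN(c3cc(Cl)cc(Cl)c3)CC2)c1C(=O)c1ccc(Cl)cc1` gives -1%. Compound 3 sits level with compound 1 at the digits reported, and the three numbers lie within the usual scatter of one another: no change at the digits printed from compound 1 to compound 3 (within the scatter), a number 3 percentage points lower from compound 2 to compound 3 (within the scatter) and a number 3 percentage points higher from compound 1 to compound 2 (within the scatter).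

Compound 4 `Nc1scc(CN2CCN(c3ccc([N+](=O)[O-])cc3)CC2)c1C(=O)c1ccc(Cl)cc1` is the next compound, not yet measured. It differs from compound 3 in one place: 4-nitrophenyl in place of 3,5-dichlorophenyl on an amine nitrogen in a ring. Going by the values given here, the steps that bear on this change are those in which the group on the same ring nitrogen was swapped, namely no change at the digits printed from compound 1 to compound 3 (within the scatter) and a number 3 percentage points lower from compound 2 to compound 3 (within the scatter), both within the scatter. On that basis compound 4 is expected to show no step beyond the scatter, a number 1 percentage points higher from compound 3 to compound 4 (within the scatter). The estimate for compound 4 in this assay is therefore 0%, expected to fall between -10% and 10%.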

Compound 4, a percentage reported as activity, at one concentration (the size of the read-out at that concentration, not a potency): -12%
The estimate for compound 4 lay 12 percentage points above the measured number, and the stated range ends above it.
By their numbers in this assay, from the lowest: compound 4; then compounds 1, 3 and 2 (each within the scatter of the next).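

The group on this ring nitrogen is not silent in this assay: 4-nitrophenyl gives a number 11 percentage points lower from compound 3 to compound 4 (beyond the scatter), a number 14 percentage points lower from compound 2 to compound 4 (beyond the scatter) and a number 11 percentage points lower from compound 1 to compound 4 (beyond the scatter), whereas the swaps among isopropyl, 2,4-dichlorophenyl and 3,5-dichlorophenyl had all stayed within the scatter. The position therefore responds to at least one change of group, and this change brings in a nitro group with two hydrogen-bond acceptors where the leaving groups had none, although a single compound cannot tie the step to that count. Nothing available bears on why the number moved.

The compounds shown leave open whether the step belongs to the nitro group itself or to its place on the phenyl ring, and how a nitrile or an amine on that ring would read. With one concentration tested, they also leave potency open.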